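Swapping dimethylcarbamoyl for isopropyl on the shared core

A few compounds are considered here, and "the series" means these few. Any claim that something is new, unique, unknown or untested is made for them only; others in the source may bear on it.

Compound 1 `Cc1cccc2c1nc(-c1c(F)cccc1F)n2Cc1c(F)cccc1F`: > 100 uM (a limit of the assay)
Compound 2 `CN(C)C(=O)c1cccc2c1nc(-c1c(F)cccc1F)n2Cc1c(F)cccc1F`: 80.1 uM

Both compounds were tested in a toxicity assay on CCRF-CEM cells (Homo sapiens) for cytotoxicity; a higher number here means that more compound is tolerated, a lower number that less compound is tolerated. In this assay, within the data shown here, compound 2 gives 80.1 uM, the only actual number available. Compound 1 gives > 100 uM, and this value is a limit of the assay.

Compound 3 `CC(C)c1cccc2c1nc(-c1c(F)cccc1F)n2Cc1c(F)cccc1F` has not yet been measured. It differs from compound 2 by isopropyl in place of dimethylcarbamoyl on an aromatic carbon.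

Among the measured compounds shown here, one measured step bears on this change: an at least 1.2-fold lower number from compound 1 to compound 2 (0.09 log units; that floor lies within the scatter). That step brought in the same dimethylcarbamoyl in place of methyl, and compound 3 gives that group up again for isopropyl. Compound 1 sits at the limit of > 100 uM in this assay, at which 1 of the 2 values shown sits, so compound 3 may also be reported only as a limit.

For the measured compounds named here, with an at least 1.2-fold lower number from compound 1 to compound 2 (0.09 log units; that floor lies within the scatter) as the only guide, a small step towards a higher number is expected in this assay, perhaps none beyond the scatter. The expected change is a 1.2-fold higher number from compound 2 to compound 3 (0.10 log units; within the scatter). For compound 3 the estimated value is 100 uM, with an expected range from 45 uM to 220 uM.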

Compound 3, half-maximal toxic concentration: 27 uM
Compound 3: the middle estimate sits 3.7-fold (0.57 log units) above what was measured, outside the stated range (below it).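

In this assay, replacing dimethylcarbamoyl with isopropyl did not carry the number back towards the limit seen with methyl but produced a 3.0-fold lower number from compound 2 to compound 3 (0.47 log units; beyond the scatter), so giving up the dimethylcarbamoyl group does not by itself mean that more compound is tolerated at this aromatic carbon. The two groups made only of carbon and hydrogen also differ clearly from each other, with an at least 3.7-fold lower number from compound 1 to compound 3 (0.56 log units; beyond the scatter), which shows that this position responds to a change from methyl to isopropyl, something the earlier step, with its floor within the scatter, could not show. Compound 1 gives > 100 uM, which is a limit of the assay, so the true size of that step stays unknown: the limit of > 100 uM in this assay, at which 1 of the 3 values shown sits.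

The compounds shown leave open whether the number keeps falling with a longer chain such as n-butyl or with a ring such as cyclopropyl, or whether isopropyl is a special case. They also leave open how a primary amine or a carboxylic acid on this aromatic carbon would compare with the three groups seen so far.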